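Methyl in place of bromo: the step to compound 3

The compounds below may be only part of what the source reports. "The series", "measured", "known", "first", "only" and "open" are said of these compounds alone.

The series shares the core of compound 1 `O=C(CCCc1ccccc1)Nc1nc2ccccc2c(=O)s1`, which in an assay on mitochondria (strain Sprague-Dawley) for inhibition of Amine oxidase [flavin-containing] B (Rattus norvegicus), read by fluorescence and Amplex Red, with stated times of 30 min and 45 min (a lower number here means a stronger inhibitor, a higher number a weaker inhibitor), gives 186 nM. Compound 2 `O=C(CCCc1ccccc1)Nc1nc2ccc(Br)cc2c(=O)s1` carries bromo in place of hydrogen on an aromatic carbon. In this assay compound 2 sits at > 10000 nM, which is a limit of the assay and not a number (the limit of > 10000 nM in this assay, at which 1 of the 2 values shown sits). The measured step is an at least 53-fold higher number from compound 1 to compound 2 (1.73 log units; beyond the scatter), so compound 2 stands at the weak end of the two values shown. Compound 3 `Cc1ccc2nc(NC(=O)CCCc3ccccc3)sc(=O)c2c1` differs from compound 2 by methyl in place of bromo on an aromatic carbon. Among the measured compounds shown here, only the step from compound 1 to compound 2 bears on this position; it was large and ran toward weaker inhibition when bromo entered. Methyl is a different group at the same aromatic carbon, so the expectation is that compound 3 lands between the two values shown, with a step of an at least 5.0-fold lower number from compound 2 to compound 3 (0.69 log units; beyond the scatter) toward a lower number. Compound 3 is estimated at 2000 nM, ranging from 500 nM to 10000 nM.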

Compound 3, half-maximal inhibitory concentration: 325 nM
Compound 3: middle estimate off by 6.2-fold (0.79 log units), on the high side; the measured number lies below the stated range.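

In this assay, a group on this aromatic carbon does not by itself weaken inhibition: with methyl there, the series shows a 1.7-fold higher number from compound 1 to compound 3 (0.24 log units; within the scatter). The exchange of bromo for methyl gives an at least 30-fold lower number from compound 2 to compound 3 (1.48 log units; beyond the scatter), so in these compounds the large shift goes with bromo and not with the mere presence of a group at this position. For compound 2 the reading is a limit of the assay and not a number, so this step has only a bound: the limit of > 10000 nM in this assay, at which 1 of the 3 values shown sits.

Going by these compounds, whether the weak reading extends to chloro or fluoro, or appears with ethyl or methoxy, stays open. Also open, on these data alone, is whether methyl on the other aromatic carbons of the shared core would behave as it does here.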